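Adding chloro to the benzyl group of compound 2

The source may hold more compounds than are shown below. What is called first, only, known or untested is meant among the compounds shown, and "the series" means these compounds.

In a functional assay on a cell-free system (plasma, Oryctolagus cuniculus) for inhibition, with stated times of 5 min, 1 min and 6 min (a higher number here means a weaker inhibitor, a lower number a stronger inhibitor), compound 1 (`CCOC(=O)c1[nH]c(-c2cccc(C#N)c2)nc1C`) reads > 30000 nM and this is a limit of the assay, not a number. Within the data shown here, compound 2 (`CCOC(=O)c1c(C)nc(-c2cccc(C#N)c2)n1OCc1ccccc1`) gives 5930 nM as the only actual number so far. Compound 3 (`CCOC(=O)c1c(C)nc(-c2cccc(C#N)c2)n1OCc1cccc(Cl)c1`) differs from it by chloro in place of hydrogen on an aromatic carbon, turning benzyloxy into (3-chlorobenzyl)oxy: chloro in place of hydrogen on an aromatic carbon is the whole change. Among the measured compounds shown here, one measured step bears on this, namely an at least 5.0-fold lower number from compound 1 to compound 2 (0.70 log units; beyond the scatter) with benzyloxy in place of hydrogen on an aromatic nitrogen. That step shows the benzyloxy group matters but does not test chloro itself. A small move towards a lower number is therefore expected, estimated as a 2.0-fold lower number from compound 2 to compound 3 (0.30 log units; within the scatter) and possibly no more than scatter. In this assay compound 3 is expected at 3000 nM with 1000 nM to 8000 nM as its estimated range.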

Compound 3, half-maximal inhibitory concentration: 19400 nM
The estimate for compound 3 lay 6.5-fold (0.81 log units) below the measured number; measured number above the stated range.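

In this assay, the benzyloxy group of compound 2 proves not to accept every addition: chloro in place of hydrogen on this aromatic carbon, meta to a large group, gives a 3.3-fold higher number from compound 2 to compound 3 (0.51 log units; beyond the scatter). The earlier step showed only that adding the whole benzyloxy group to the nitrogen lowers the number, whereas this one shows that a single added chlorine on that group can move it back towards a weaker inhibitor. What can still be said against compound 1 is an at least 1.5-fold lower number from compound 1 to compound 3 (0.18 log units; that floor lies within the scatter), and this comparison gives only a floor: the limit of > 30000 nM in this assay, at which 1 of the 3 values shown sits.

The compounds shown leave open whether this rise belongs to chloro itself or to its place, as no other aromatic carbon of that ring carries it. As far as these compounds go, how fluoro, methoxy or an amine would read at the same place also remains open.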